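Silyl Ether Removal on a Cyclopentenone Pair

The compounds below may be only part of what the source reports. "The series", "measured", "known", "first", "only" and "open" are said of these compounds alone.

Measured compounds:
- Compound 1, `COc1ccc(C2=C(c3cc(OC)c(OC)c(OC)c3)C(=O)C(O)C2)cc1`: in an ADME assay on KB cells (Homo sapiens) for cytotoxicity, read by MTT assay, with a stated time of 72 h (on this read-out higher numbers stand for weaker inhibition and lower numbers for stronger inhibition), compound 1 gives < 1 ug/mL, which is a limit of the assay and not a number.
- Compound 3, `COc1ccc(C2=C(c3cc(OC)c(OC)c(OC)c3)C(=O)C(O[SiH2]C(C)(C)C)C2)cc1`: in this assay compound 3 gives 7 ug/mL.
- Compound 2, `COc1ccc(OC)c(C2=C(c3cc(OC)c(OC)c(OC)c3)C(=O)CC2O[SiH2]C(C)(C)C)c1`: in this assay compound 2 gives 10 ug/mL.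

Compound 3 and compound 2 carry the same silyl ether; the difference between their two cores is not broken down here. Their values in this assay sit within the scatter of each other, so no order between them is claimed.

Compound 3 and compound 1 differ by a hydrogen atom in place of a group of 5 heavy atoms (4 carbon, 1 silicon; no ring), on an oxygen on a saturated carbon. That change gave an at least 7.0-fold lower number from compound 3 to compound 1 (0.84 log units; beyond the scatter), and since compound 1 sits at the limit of < 1 ug/mL in this assay, at which 1 of the 3 values shown sits, the true size of that step is not known.

Compound 4, `COc1ccc(OC)c(C2=C(c3cc(OC)c(OC)c(OC)c3)C(=O)CC2O)c1`, is not yet measured. It differs from compound 2 by a hydrogen atom in place of a group of 5 heavy atoms (4 carbon, 1 silicon; no ring), on an oxygen on a saturated carbon, the same change as between compound 3 and compound 1. The step is expected to be a 6.7-fold lower number from compound 2 to compound 4 (0.82 log units; beyond the scatter), resting on compound 3 and compound 1 and their an at least 7.0-fold lower number from compound 3 to compound 1 (0.84 log units; beyond the scatter). Compound 4 is therefore expected to give 1.5 ug/mL in this assay, estimated between 0.3 ug/mL and 5 ug/mL.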

Compound 4, half-maximal inhibitory concentration: > 100 ug/mL
Compound 4 gave a limit, no number; the forecaster's own chance of this, stated with the estimate: 35%; middle value at least 66-fold (1.82 log units) from the limit.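

On the core of compound 4, exchanging the silyl ether for a hydrogen atom gave an at least 10-fold higher number from compound 2 to compound 4 (1.00 log units; beyond the scatter). In this assay compound 4 gives > 100 ug/mL, which is a limit of the assay and not a number, so the true size of that step is not known. The same change went in opposite directions on the two cores, so its result does not carry from one core to the other in this series, although two pairs do not show what in the cores decides the direction: the same change on two cores in this assay, an at least 7.0-fold lower number (0.84 log units; beyond the scatter) from compound 3 to compound 1 and an at least 10-fold higher number (1.00 log units; beyond the scatter) from compound 2 to compound 4, at least 70-fold (1.84 log units) apart, beyond the scatter of two such steps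

The compounds shown leave open how other groups on that oxygen, such as a methyl ether or an acetyl ester, would behave on each of the two cores. They also leave open whether an amine in place of the hydroxyl would follow the pattern of compound 1 or that of compound 4.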